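A few compounds are considered here, and "the series" means these few. Any claim that something is new, unique, unknown or untested is made for them only; others in the source may bear on it.

Measured so far in a functional assay on NCI/ADR-RES cells (Homo sapiens) for inhibition; a higher number here means a weaker inhibitor of growth, a lower number a stronger inhibitor of growth:
compound 1 `O=S(=O)(/C=C/c1ccc(Br)cc1)Cc1ccc(Nc2ncnc3ccccc23)cc1`: > 100000 nM (a limit, not a number)
compound 2 `O=S(=O)(/C=C/c1ccc(C(F)(F)F)cc1F)Cc1ccc(Nc2ncnc3ccccc23)cc1`: 100000 nM

Among the measured compounds shown here, compound 2 holds the only true number in this small set. Compound 1 gives only a limit: the limit of > 100000 nM in this assay, at which 1 of the 2 values shown sits. For the measured compounds named here, the one measured step, a number no higher from compound 1 to compound 2 (the limit leaves the size open), exchanges the aryl group on the double-bonded chain. Its size cannot be read, and it concerns a different place from the one now in question.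

Compound 3 `O=S(=O)(/C=C/c1ccc(C(F)(F)F)cc1F)Cc1ccc(Nc2ncnc3ccc(Br)cc23)cc1` keeps everything in compound 2 except one change on the shared core: bromo in place of hydrogen on an aromatic carbon. In words, this is bromo in place of hydrogen on an aromatic carbon. Going by the values given here, no measured step touches this place, so the data give no size for such a change, and no direction either. The expectation therefore stays close to the value of compound 2, 100000 nM, with a wide margin for the unknown. The expected change is a 1.7-fold lower number from compound 2 to compound 3 (0.22 log units; within the scatter), which is not clearly beyond the usual scatter. For compound 3 the estimated value is 60000 nM, with an expected range from 12000 nM to 100000 nM.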

Compound 3, concentration for 50% growth inhibition: 85000 nM
Beside the measured number, compound 3's estimate is 1.4-fold (0.15 log units) below it; low and high end bracket the measured number.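

In this assay, bromo in place of hydrogen on this aromatic carbon of the shared core gives a 1.2-fold lower number from compound 2 to compound 3 (0.07 log units; within the scatter). Among the compounds shown here, this is the first measured size for any change at this place, and it shows that bromo and hydrogen here cannot be told apart in this assay, with the two compounds reading as one result within the usual scatter. The set as a whole still sits at the weak end of the scale, and compound 1 remains a limit, not a number: the limit of > 100000 nM in this assay, at which 1 of the 3 values shown sits.

Going by these compounds, the step from compound 1 to compound 2 cannot be read, so how the aryl group on the double-bonded chain and the bromo on the core might act together remains open. One group at one carbon also says little about the place in general: an amine, a methoxy group or a carboxylic acid on this same aromatic carbon might read quite differently, and the compounds shown give no value for any of them.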